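Truncating the anilide of compound 1 to a primary amide

The compounds below may be only part of what the source reports. "The series", "measured", "known", "first", "only" and "open" are said of these compounds alone.

Compound 1 `Cc1cccc(C)c1NC(=O)CSc1nnc(-c2ccoc2C)n1Cc1ccco1` carries 2,6-dimethylphenyl on an amide-type nitrogen. In a functional assay on CHO cells for antagonist activity at Orexin receptor type 2 (Homo sapiens), read by FLIPR and calcium flux (a lower number here means a stronger inhibitor, a higher number a weaker inhibitor), compound 1 gives > 15800 nM, which is a limit of the assay and not a number (the limit of > 15800 nM in this assay, at which 1 of the 2 values shown sits). Compound 2 `Cc1occc1-c1nnc(SCC(=O)Nc2cccc(F)c2)n1Cc1ccco1` differs from it in one place, and in this assay compound 2 gives 501 nM; the step of an at least 31-fold lower number from compound 1 to compound 2 (1.49 log units; beyond the scatter) shows that the group on the amide-type nitrogen moves the read-out strongly. Compound 3 `Cc1occc1-c1nnc(SCC(N)=O)n1Cc1ccco1` is not yet measured; its change from compound 1 is hydrogen in place of 2,6-dimethylphenyl on an amide-type nitrogen. Within the data shown here, the one measured step bears only indirectly: there one aromatic group replaced another, whereas here the aromatic group is removed altogether, and no measured pair shows what that removal does. Compound 1 sits at a limit, so a step to compound 3 can only be told as the gap between a limit and a number. For compound 3 the expected step is an at least 1.0-fold lower number from compound 1 to compound 3 (0.02 log units; that floor lies within the scatter), most likely none beyond the scatter, with the assay again likely to report only a limit. Compound 3 is estimated in this assay at 15000 nM, range 3000 nM to 60000 nM.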

Compound 3, inhibition constant: > 15800 nM
Compound 3: only a limit was reported; the forecaster's own chance of this, stated with the estimate: 60%; middle value at least 1.0-fold (0.02 log units) from the limit.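

In this assay, hydrogen in place of 3-fluorophenyl on an amide-type nitrogen gives an at least 31-fold higher number from compound 2 to compound 3 (1.49 log units; beyond the scatter), so the read-out of compound 2 does not survive loss of that aromatic group. Compound 3 gives > 15800 nM, which is a limit of the assay and not a number. Of the two aryl groups and hydrogen now compared at this place, only 3-fluorophenyl gives a value short of the limit, while compound 1 and compound 3 both end at it, and the step between those two cannot be read: the limit of > 15800 nM in this assay, at which 2 of the 3 values shown sit.

Open, going by these compounds, is how much of the read-out of compound 2 belongs to the aromatic ring itself and how much to the fluorine on it, a question that unsubstituted phenyl on the same nitrogen would address, while 2-methylphenyl would separate the effect of a single methyl from that of the 2,6-dimethylphenyl pattern of compound 1. Also open, on these data alone, is whether an aromatic ring is required here at all, or whether a saturated ring such as cyclohexyl, or a small alkyl such as methyl, would give a value short of the limit in this assay.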